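The compounds below may be only part of what the source reports. "The series", "measured", "known", "first", "only" and "open" are said of these compounds alone.

Values measured in an ADME assay on the whole organism (Rattus norvegicus, strain Sprague-Dawley) for pharmacokinetics, using cassette dosing, at a dose of 0.5 mg/kg by the intravenous route; a higher number here means faster removal of the compound, a lower number slower removal:

- Compound 1 `O=C(c1cc(-c2ccc(=O)[nH]c2)on1)N1CCC(Cc2ccc(Cl)cc2)CC1`: 5.4 mL/min/kg
- Compound 2 `COc1ccc(N2CCN(C(=O)C(=O)Nc3ccc4[nH]c(=O)oc4c3)CC2)cc1`: "not determined" (no result reported)
- Compound 3 `O=C(Nc1ccc2[nH]c(=O)oc2c1)C(=O)N1CCN(c2ccc(F)c(F)c2)CC1`: 4 mL/min/kg

Only two of these compounds have a number. Compound 3 at 4 mL/min/kg and compound 1 at 5.4 mL/min/kg lie within the usual scatter of each other, so this assay does not separate them. Compound 2 has no number and offers no guide.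

Compound 4 `COc1ccc(N2CCN(C(=O)C(=O)Nc3ccc4[nH]c(=O)oc4c3)CC2)cc1F` is built from compound 3 by one small edit: methoxy in place of fluoro on an aromatic carbon. In words, methoxy takes the place of fluoro on an aromatic carbon, ortho to a fluoro group and para to a large group, turning 3,4-difluorophenyl into 3-fluoro-4-methoxyphenyl.

For the measured compounds named here, no measured pair here shows what this swap does, so the expectation stays close to compound 3 and the range is kept wide. A small upward move within the scatter is expected, an estimated 1.8-fold higher number from compound 3 to compound 4 (0.24 log units; within the scatter). In this assay the estimate for compound 4 is 7 mL/min/kg, with an expected range from 3 mL/min/kg to 18 mL/min/kg.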

Compound 4, clearance: 101 mL/min/kg
Compound 4: the middle estimate sits 14-fold (1.16 log units) below what was measured; the measured number lies above the stated range.
By their numbers in this assay, from the lowest: compounds 3 and 1 (each within the scatter of the next); then compound 4.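

In this assay, the step from 3,4-difluorophenyl to 3-fluoro-4-methoxyphenyl gives a 25-fold higher number from compound 3 to compound 4 (1.40 log units; beyond the scatter). For the compounds shown here, this shows that the aromatic carbon para to the large group is a sensitive position: one swap of fluoro for methoxy there moves removal from the rat far beyond the scatter, whereas the earlier numbers alone showed no step at all. Nothing measured here accounts for the jump, so its cause remains unknown.

Going by these compounds, compound 2 carries methoxy at this position without the ortho fluoro group, but it has no number, so what that fluoro group contributes remains open. Nor can these compounds tell whether the high number is specific to methoxy or would also appear with another group at this position, such as ethoxy or an amine.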